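A few compounds are considered here, and "the series" means these few. Any claim that something is new, unique, unknown or untested is made for them only; others in the source may bear on it.

Measured in a functional assay on K562 cells (Homo sapiens) for inhibition, read by MTT assay, with a stated time of 48 h; a higher number here means a weaker inhibitor, a lower number a stronger inhibitor:
compound 1 `CC(C)(C)OC(=O)N1C[C@@H](n2cc(-c3ccc(N)nc3)nn2)C[C@H]1C(=O)Nc1ccc(Cl)c(C(F)(F)F)c1`: 4710 nM
compound 2 `Nc1nc2ccc(-c3cn([C@@H]4CN[C@H](C(=O)Nc5ccc(Cl)c(C(F)(F)F)c5)C4)nn3)nc2s1`: 26200 nM
compound 3 `CC(=O)Nc1nc2ccc(-c3cn([C@@H]4CN[C@H](C(=O)Nc5ccc(Cl)c(C(F)(F)F)c5)C4)nn3)nc2s1`: 10000 nM

Compound 3 lies in the middle of these three numbers. Its value is higher than that of compound 1 and lower than that of compound 2, and both gaps lie beyond the usual scatter of repeat measurements.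

Compound 4 `O=C(Nc1nc2ccc(-c3cn([C@@H]4CN[C@H](C(=O)Nc5ccc(Cl)c(C(F)(F)F)c5)C4)nn3)nc2s1)C1CC1` has not yet been measured in this assay. It differs from compound 3 in one group: cyclopropyl in place of methyl on a carbonyl carbon. Put simply, cyclopropyl stands in place of methyl on a carbonyl carbon, turning acetyl into cyclopropylcarbonyl.

Among the measured compounds shown here, only one measured step bears on this change: a 2.6-fold lower number from compound 2 to compound 3 (0.42 log units; beyond the scatter). There, acetyl took the place of hydrogen on a nitrogen on an aromatic ring, and that acetyl is the group altered in compound 4. For the measured compounds named here, no measured pair makes the methyl to cyclopropyl swap itself, so this evidence is indirect. Going by the values given here, with that modest step as the only guide, a smaller move in the same direction, toward a lower number, is expected, and it may not rise above the scatter. The estimated step is a 1.3-fold lower number from compound 3 to compound 4 (0.10 log units; within the scatter). For compound 4 the estimated value is 8000 nM, with an expected range from 3000 nM to 20000 nM.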

Compound 4, half-maximal inhibitory concentration: 16200 nM
Beside the measured number, compound 4's estimate is 2.0-fold (0.31 log units) below it, and the stated range covers the measured number.
By their numbers in this assay, from the lowest: compound 1; then compounds 3, 4 and 2 (each within the scatter of the next, the first and the last beyond it).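

In this assay, changing the group on the carbonyl carbon from methyl to cyclopropyl gives a 1.6-fold higher number from compound 3 to compound 4 (0.21 log units; within the scatter), so this swap cannot be told apart from repeat-measurement noise. Placing cyclopropylcarbonyl on the free amino nitrogen gives a 1.6-fold lower number from compound 2 to compound 4 (0.21 log units; within the scatter), whereas acetyl on the same nitrogen gave a 2.6-fold lower number from compound 2 to compound 3 (0.42 log units; beyond the scatter); the clear shift seen with acetyl is therefore not matched clearly by the second acyl group, and compound 4 sits within the scatter of both compound 2 and compound 3, even though those two lie beyond the scatter of each other. Nothing measured here explains this result.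

The compounds shown leave open whether another group on that nitrogen, such as benzoyl, propanoyl with its longer chain, or methanesulfonyl, would move the number beyond the scatter in either direction. They also cannot show how these acylated compounds relate to compound 1, which differs from them in more than one place.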